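Dimethylaminopropyl on the ring nitrogen across two aryl cores

A few compounds are considered here, and "the series" means these few. Any claim that something is new, unique, unknown or untested is made for them only; others in the source may bear on it.

Compound 1 `Cc1nn(C)c2c1C(c1cccc(F)c1)=NCCN2` carries a hydrogen on the ring nitrogen of its seven-membered ring. In a functional assay on the whole organism for positive allosteric modulation, with Rattus norvegicus as the target (a lower number here means that less compound is needed, a higher number that more compound is needed for the effect), compound 1 gives 2.5 mg/kg. Compound 2 `Cc1nn(C)c2c1C(c1cccc(F)c1)=NCCN2CCCN(C)C` differs from compound 1 by 3-(dimethylamino)propyl in place of hydrogen on a nitrogen on an aromatic ring in a ring. For compound 2 the result in this assay is a limit of the assay, > 10 mg/kg. That change produced an at least 4.0-fold higher number from compound 1 to compound 2 (0.60 log units; beyond the scatter), with the value of compound 2 sitting at the limit of > 10 mg/kg in this assay, at which 1 of the 3 values shown sits.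

Compound 3 `Cc1ccc(C2=NCCNc3c2c(C)nn3C)cc1` has another core; the difference between the two cores is not broken down here. In this assay compound 3 gives 2.5 mg/kg, level with compound 1 and within the scatter of it.

Compound 4 `Cc1ccc(C2=NCCN(CCCN(C)C)c3c2c(C)nn3C)cc1` is not yet measured. It differs from compound 3 by 3-(dimethylamino)propyl in place of hydrogen on a nitrogen on an aromatic ring in a ring. Among the compounds with values here, this is the same kind of change as the one from compound 1 to compound 2, not the same one: around the place, the ring atom three ring bonds from the ring nitrogen bears a 4-methylphenyl group in compound 3 where compound 1 has a 3-fluorophenyl group.

Within the data shown here, a step of comparable size is expected here, a 4.0-fold higher number from compound 3 to compound 4 (0.60 log units; beyond the scatter), because the single measured instance of this change, an at least 4.0-fold higher number from compound 1 to compound 2 (0.60 log units; beyond the scatter), ran out to a limit. Among the measured compounds shown here, with only one precedent, the size of the expected step is uncertain. Compound 4 is therefore expected to need about 10 mg/kg in this assay, most likely between 4 mg/kg and 30 mg/kg, with a real chance that only a limit is reported.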

Compound 4, minimum effective dose: > 10 mg/kg
Compound 4: only a limit was reported; the forecaster's own chance of this, stated with the estimate: 65%; the middle value lies on the limit itself.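

On the core of compound 3, 3-(dimethylamino)propyl in place of hydrogen on a nitrogen on an aromatic ring in a ring gives an at least 4.0-fold higher number from compound 3 to compound 4 (0.60 log units; beyond the scatter), so in this assay the change moves the number in the same direction on both cores shown. Compound 4 gives > 10 mg/kg, a limit of the assay, and this is the second compound in the series to sit there: the limit of > 10 mg/kg in this assay, at which 2 of the 4 values shown sit. This shows that the higher number seen on the core of compound 1 carries over to a core with a 4-methylphenyl group, but it does not give the true size of the step on either core or show that the two sizes match: the same change on two cores in this assay, an at least 4.0-fold higher number (0.60 log units; beyond the scatter) from compound 1 to compound 2 and an at least 4.0-fold higher number (0.60 log units; beyond the scatter) from compound 3 to compound 4; the limit leaves it open whether they differ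

On these data alone, the step from compound 2 to compound 4 cannot be read, so it stays open whether 4-methylphenyl and 3-fluorophenyl differ once the chain is in place. Also open, as far as these compounds go, is whether the higher number goes with the chain or with its terminal dimethylamine, a question that a plain propyl chain, a shorter chain ending in the same amine, or a chain ending in a carboxylic acid on that nitrogen would address.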